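The compounds below may be only part of what the source reports. "The series", "measured", "known", "first", "only" and "open" are said of these compounds alone.

Compound 2 `CCc1nnc(SCc2ccccc2)n1N1C(=O)c2ccccc2C1=O` sits at the edge of what a functional assay on PC-3M cells (Homo sapiens) for cytotoxicity, read by MTT assay, with a stated time of 48 h (on this read-out higher numbers stand for weaker inhibition and lower numbers for stronger inhibition), can report. In this assay compound 2 gives > 200000 nM, which is a limit of the assay rather than a measured number. Its close relative compound 1 `Cc1nnc(SCc2ccccc2)n1N1C(=O)c2ccccc2C1=O` likewise gives > 200000 nM in this assay, again a limit. Going by the values given here, the only measured step, a step that the two limits leave unreadable from compound 1 to compound 2, therefore cannot be read, and the limit of > 200000 nM in this assay, at which 2 of the 2 values shown sit, shows both values resting at that same limit.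

Compound 3 `CCOC(=O)CSc1nnc(CC)n1N1C(=O)c2ccccc2C1=O` differs from compound 2 by ethoxycarbonyl in place of phenyl on a saturated chain carbon bound to a sulfur. Among the compounds with values here, no measured step touches this change, and the single step that exists, a step that the two limits leave unreadable from compound 1 to compound 2, gives no readable size, so there is nothing to support an expectation of a step beyond the scatter in this assay. Compound 3 is estimated at 300000 nM, with a range from 100000 nM to 1000000 nM. That expectation amounts to a step that the limit leaves unreadable from compound 2 to compound 3.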

Compound 3, half-maximal inhibitory concentration: > 200000 nM
Compound 3: only a limit was reported; the forecaster's own chance of this, stated with the estimate: 80%; the middle value does not contradict the limit.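

Compound 3 gives > 200000 nM in this assay, which is a limit and not a number. No step can be read between compound 2 and compound 3: the limit of > 200000 nM in this assay, at which 3 of the 3 values shown sit. The compounds shown leave open what the true value of each one is, and whether ethoxycarbonyl in place of phenyl changes anything.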